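The source may hold more compounds than are shown below. What is called first, only, known or untested is meant among the compounds shown, and "the series" means these compounds.

Measured in a functional assay on HCT-116 cells (Homo sapiens) for inhibition, read by MTT assay, with a stated time of 72 h; on this read-out higher numbers stand for weaker inhibition and lower numbers for stronger inhibition:
- compound 1 `Nc1ncnc2c1c(-c1cnc3[nH]ccc3c1)nn2CCCCCCC(=O)NO`: 9860 nM
- compound 2 `Nc1nc2cc(-c3nn(CC(=O)NO)c4ncnc(N)c34)ccc2o1`: 11400 nM

Compound 2 lies within the scatter of compound 1, so the two values do not separate the compounds in this assay. Going by the values given here, no measured pair differing in one place is available as a guide.

Compound 3 `Nc1nc2cc(-c3nn(CCCCCCC(=O)NO)c4ncnc(N)c34)ccc2o1` remains unmeasured. The change is 5-(hydroxycarbamoyl)pentyl in place of hydroxycarbamoyl on a saturated chain carbon bound to an aromatic nitrogen. Cut one bond further out, (hydroxycarbamoyl)methyl becomes 6-(hydroxycarbamoyl)hexyl.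

The closest evidence is compound 1, which also carries 6-(hydroxycarbamoyl)hexyl and gives 9860 nM. This gives no sign that the longer chain alone brings a large gain. Compound 1 differs from compound 3 elsewhere, however, so it is only a loose guide, and the range has to stay wide. A modest move toward stronger inhibition is expected, though the data do not exclude no change. The expected size is a 3.8-fold lower number from compound 2 to compound 3 (0.58 log units; beyond the scatter). For compound 3 the estimated value is 3000 nM, with an expected range from 400 nM to 15000 nM.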

Compound 3, half-maximal inhibitory concentration: 5390 nM
Estimate against measurement, compound 3: 1.8-fold (0.25 log units) below, and the stated range covers the measured number.
By their numbers in this assay, from the lowest: compounds 3, 1 and 2 (each within the scatter of the next, the first and the last beyond it).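

Going by these compounds alone, on a saturated chain carbon bound to an aromatic nitrogen, 5-(hydroxycarbamoyl)pentyl in place of hydroxycarbamoyl gives, in this assay, a 2.1-fold lower number from compound 2 to compound 3 (0.33 log units; beyond the scatter) and so provides the first single-place evidence that this position responds to the change, with the size of the response only modest. With 6-(hydroxycarbamoyl)hexyl held constant, exchanging the aromatic group on an aromatic carbon gives a 1.8-fold lower number from compound 1 to compound 3 (0.26 log units; within the scatter) and therefore does not separate the two compounds in this assay. No measurement on hand gives a reason for either result.

The compounds shown cover only the two ends of the chain comparison, so the shape of the response between (hydroxycarbamoyl)methyl and 6-(hydroxycarbamoyl)hexyl remains open, as does the effect of a longer chain on the core of compound 3. As far as these compounds go, it also remains open whether hydroxycarbamoyl is required at the chain end, which a carboxylic acid or a primary amide on 6-carbon-length chains of the same compound could test.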